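Swapping the pendant aryl ring in a statin-like lactone series

A few compounds are considered here, and "the series" means these few. Any claim that something is new, unique, unknown or untested is made for them only; others in the source may bear on it.

Compound 2 `Cc1cc(-c2cc(Cl)cc(Cl)c2/C=C/[C@@H]2C[C@@H](O)CC(=O)O2)ccc1F` gives 29 nM in an assay for inhibition of 3-hydroxy-3-methylglutaryl-coenzyme A reductase (Rattus norvegicus) (on this read-out lower numbers stand for stronger inhibition and higher numbers for weaker inhibition), the highest of the three numbers measured; compound 1 `Cc1cc(-c2cc(Cl)cc(C)c2/C=C/[C@@H]2C[C@@H](O)CC(=O)O2)ccc1F` gives 6 nM and compound 3 `Cc1cc(Cl)c(/C=C/[C@@H]2C[C@@H](O)CC(=O)O2)c(-c2ccc(F)c(C)c2)c1` gives 13 nM. Compound 4 `O=C1C[C@H](O)C[C@@H](/C=C/c2c(Cl)cc(Cl)cc2-c2ccc(Cl)c(Cl)c2)O1` carries 3,4-dichlorophenyl in place of 4-fluoro-3-methylphenyl on an aromatic carbon. The measured steps, a 4.8-fold higher number from compound 1 to compound 2 (0.68 log units; beyond the scatter) and a 2.2-fold lower number from compound 2 to compound 3 (0.35 log units; beyond the scatter), both concern exchanges of methyl and chloro elsewhere on the shared core rather than on the pendant ring, so they bear only loosely on this change; they show that chloro in place of a methyl group tended toward higher numbers. Compound 4 is therefore expected to show a modest rise, a 1.7-fold higher number from compound 2 to compound 4 (0.24 log units; within the scatter), in this assay. The estimate for compound 4 is 50 nM, with a likely range from 15 nM to 160 nM.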

Compound 4, half-maximal inhibitory concentration: 25 nM
For compound 4 the middle estimate is 2.0-fold (0.30 log units) above the measured one, within the range that was stated.
By their numbers in this assay, from the lowest: compound 1; then compounds 3, 4 and 2 (each within the scatter of the next, the first and the last beyond it).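

In this assay, within the data shown here, the pendant ring itself changes for the first time: 3,4-dichlorophenyl in place of 4-fluoro-3-methylphenyl gives a 1.2-fold lower number from compound 2 to compound 4 (0.06 log units; within the scatter) on the core of compound 2. At this position, ortho to a large group, the two rings therefore cannot be told apart, whereas the methyl and chloro exchanges on the core gave steps beyond the scatter. No measurement available here offers an explanation for this result. Still open, going by these compounds, is how the number would respond to a pendant ring carrying an amine or a carboxylic acid.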